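Moving the Methyl on the Fluorophenyl Ring

This account rests on a few compounds, and the source may have more. Where it says the series, first, only, none or still open, it means among the compounds named here.

Of the compounds shown here, three sharing one core have been measured in an assay for inhibition of 3-hydroxy-3-methylglutaryl-coenzyme A reductase (Rattus norvegicus); a lower number here means a stronger inhibitor, a higher number a weaker inhibitor. Compound 1 `O=C1C[C@H](O)C[C@@H](/C=C/c2c(Cl)cc(Cl)cc2-c2cc(Cl)cc(Cl)c2)O1` gives 37 nM, compound 2 `Cc1cccc(-c2cc(Cl)cc(Cl)c2/C=C/[C@@H]2C[C@@H](O)CC(=O)O2)c1` gives 16 nM, and compound 3 `Cc1cc(-c2cc(Cl)cc(Cl)c2/C=C/[C@@H]2C[C@@H](O)CC(=O)O2)ccc1F` gives 29 nM. Compound 3 stands second highest of the three, with compound 1 as its nearest neighbour; its gaps to both compound 1 and compound 2 lie within the usual scatter of this assay, so no order among them can be claimed. Replacing the 3,5-dichlorophenyl with 3-methylphenyl gave a 2.3-fold lower number from compound 1 to compound 2 (0.36 log units; beyond the scatter), a modest gain beyond the scatter, whereas the replacement with 4-fluoro-3-methylphenyl gave a 1.3-fold lower number from compound 1 to compound 3 (0.11 log units; within the scatter), within it.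

Compound 4 `Cc1cc(F)ccc1-c1cc(Cl)cc(Cl)c1/C=C/[C@@H]1C[C@@H](O)CC(=O)O1` differs from compound 3 only in where the methyl sits: 4-fluoro-2-methylphenyl in place of 4-fluoro-3-methylphenyl on an aromatic carbon. Among the measured compounds shown here, none of the measured steps moves a methyl from one position to another, so none bears directly on this change; the closest, adding the fluorine, gave a 1.8-fold higher number from compound 2 to compound 3 (0.26 log units; within the scatter), within the scatter. With no guide in either direction, for compound 4 the expected step is a 1.2-fold higher number from compound 3 to compound 4 (0.08 log units; within the scatter), that is, none beyond the scatter. Compound 4 is therefore estimated at 35 nM, with a likely range from 12 nM to 110 nM.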

Compound 4, half-maximal inhibitory concentration: 36 nM
Estimate against measurement, compound 4: 1.0-fold (0.01 log units) below; measured number inside the range.
By their numbers in this assay, from the lowest: compounds 2, 3, 4 and 1 (each within the scatter of the next, the first and the last beyond it).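

Moving the methyl, so that 4-fluoro-2-methylphenyl replaces 4-fluoro-3-methylphenyl, gives a 1.2-fold higher number from compound 3 to compound 4 (0.09 log units; within the scatter) in this assay and so leaves no mark that can be told from the scatter, with the fluorine present in both compounds. Going from the unfluorinated 3-methylphenyl to 4-fluoro-2-methylphenyl changes two things at once and gives a 2.3-fold higher number from compound 2 to compound 4 (0.35 log units; beyond the scatter) as a modest step, which is the first step involving fluorine to pass beyond the scatter. Replacing 3,5-dichlorophenyl with 4-fluoro-2-methylphenyl gives a 1.0-fold lower number from compound 1 to compound 4 (0.01 log units; within the scatter) and so shows that this quite different ring can stand in for the dichlorinated one with no visible change in the number.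

As far as these compounds go, whether a methoxy or an ethyl in place of this methyl would also leave the number unchanged stays open. Nothing available here explains these numbers.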